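From pyrrolidin-1-yl to cyclohexylamino at the cytotoxicity limit

The source may hold more compounds than are shown below. What is called first, only, known or untested is meant among the compounds shown, and "the series" means these compounds.

- Compound 1 `CCOc1nc(N)nc2c1ncn2/C=C1/CC1(CO)CO` gives > 300000 nM (a limit)
- Compound 2 `Nc1nc(N2CCCC2)c2ncn(/C=C3/CC3(CO)CO)c2n1` gives > 300000 nM (a limit)

In an ADME assay on HFF cells (Homo sapiens) for cytotoxicity, with a stated time of 8 days (on this read-out lower numbers stand for higher toxicity in this test and higher numbers for lower toxicity in this test), compound 2 gives no exact number, only a limit of the assay (> 300000 nM). Compound 3 `Nc1nc(NC2CCCCC2)c2ncn(/C=C3/CC3(CO)CO)c2n1` differs from compound 2 in one place (cyclohexylamino in place of pyrrolidin-1-yl on an aromatic carbon), where cyclohexylamino stands in place of pyrrolidin-1-yl on an aromatic carbon. Among the compounds with values here, the only measured step at this place is a step that the two limits leave unreadable from compound 1 to compound 2 and it gives no size to carry over. Both measured compounds share one result, the limit of > 300000 nM in this assay, at which 2 of the 2 values shown sit, and neither gives a true number to start from. For compound 3, no step beyond the usual scatter is therefore expected in this assay in either direction. Expected here is a number no higher from compound 2 to compound 3 (the limit leaves the size open) and so no clear change. Compound 3 is estimated at 300000 nM (expected range 100000 nM to 500000 nM).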

Compound 3, half-maximal cytotoxic concentration: > 300000 nM
Compound 3: no number, only a limit; the forecaster's own chance of this, stated with the estimate: 70%; the middle value sits exactly at the limit.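

No step can be read among compound 1, compound 2 and compound 3, since all three stop at the same limit: the limit of > 300000 nM in this assay, at which 3 of the 3 values shown sit.

Whether ethoxy, pyrrolidin-1-yl and cyclohexylamino differ at all in this assay stays open, as none of these compounds has a true number there.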